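Removing the chloro from compound 1

The compounds below may be only part of what the source reports. "The series", "measured", "known", "first", "only" and "open" are said of these compounds alone.

Measured compounds:
compound 1, `O=C1OC(c2ccc(Cl)c([N+](=O)[O-])c2)=N/C1=C\c1ccncc1`: 10%
compound 2, `O=C1OC(c2ccc(Cl)c([N+](=O)[O-])c2)=N/C1=C\c1cccnc1`: 100%

Going by the values given here, in an assay on isolated protein for inhibition of Death-associated protein kinase 3 (Homo sapiens), tested at 10 uM (a higher number here means a stronger effect of the compound at the concentration tested, a lower number a weaker effect), compound 1 gives 10%, the lower of the two numbers known. Among the compounds with values here, its only neighbour is compound 2, which gives 100% in this assay, and the one step that has been measured, a number 90 percentage points higher from compound 1 to compound 2 (beyond the scatter), comes from pyridin-3-yl in place of pyridin-4-yl on a double-bonded chain carbon bound to a double-bonded ring carbon.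

The step now followed leads from compound 1 to compound 3, `O=C1OC(c2cccc([N+](=O)[O-])c2)=N/C1=C\c1ccncc1`, which is yet to be measured in this assay. The change is hydrogen in place of chloro on an aromatic carbon: chloro leaves and hydrogen enters, on an aromatic carbon of a six-membered aromatic ring of carbon only, ortho to a nitro group and para to a large group. Within the data shown here, no measured step touches this position; the only step known, from compound 1 to compound 2, alters a different ring and says nothing about the chloro. With no guide among the measured compounds, compound 3 is expected to stay close to compound 1, a step of a number 2 percentage points higher from compound 1 to compound 3 (within the scatter), that is, none beyond the scatter. The estimate for compound 3 in this assay is 12%, within 0% to 40%.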

Compound 3, a percentage reported as inhibition, at one concentration (the size of the read-out at that concentration, not a potency): 0%
Estimate against measurement, compound 3: 12 percentage points above; the measured number falls inside the stated range.
By their numbers in this assay, from the lowest: compounds 3 and 1 (each within the scatter of the next); then compound 2.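

In this assay, the chloro on the aromatic carbon ortho to a nitro group and para to a large group now has a measured step of its own: a number 10 percentage points lower from compound 1 to compound 3 (within the scatter). Hydrogen in place of chloro at this carbon therefore gives no difference that can be read while pyridin-4-yl is present, and with compound 3 at 0% and compound 1 at 10%, both numbers lie so low that the step cannot show whether the chloro contributes anything in a more active compound. No independent evidence bears on this result, so nothing can be said about the reason for it.

The compounds shown leave open whether the chloro counts for more alongside pyridin-3-yl, where compound 2 gives 100%, since only the counterpart of compound 2 with hydrogen on this carbon could settle that. Going by these compounds, it also remains open whether a methyl, a methoxy or an amine on the same carbon would match hydrogen and chloro in this assay or move the number beyond the scatter.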